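The source may report more compounds than this note shows. Statements on the series, on what has been measured and on what is new or still open speak of the compounds shown alone.

In an assay on isolated protein for inhibition of high affinity nerve growth factor receptor (Homo sapiens), read by HTRF, tested at 10 uM (on this read-out lower numbers stand for less inhibition and higher numbers for more inhibition at the one concentration tested (going by the name of the read-out)), three compounds have been measured so far. Compound 1 `CN(CCCn1ccnc1)C(=O)[C@@H]1CCCN1c1nccc(Nc2ccccc2)n1` gives 11%. Compound 3 `O=C(C1CCN(c2nccc(Nc3ccccc3)n2)CC1)N1CC[C@@H](O)C1` gives 12%, a number within the usual scatter of that of compound 1, so the two cannot be told apart. Compound 2 `CC(=O)CCCCC(=O)N1CCN(c2nccc(Oc3cccc(C)c3)n2)CC1` gives 0%, which lies beyond the scatter below compound 1. Compound 4 `CN(C)CC(C)(C)CNC(=O)[C@@H]1CCCN1c1nccc(Nc2ccccc2)n1` has not yet been measured. It differs from compound 1 in one place: (2-((dimethylamino)methyl)-2-methylpropyl)amino in place of (3-(1H-imidazol-1-yl)propyl)(methyl)amino on a carbonyl carbon. The shared core and the carbonyl carbon on the saturated ring carbon stay the same. For the measured compounds named here, no measured pair shows the effect of such a change, so the estimated step is a number 1 percentage points lower from compound 1 to compound 4 (within the scatter), small and in no direction beyond the scatter. Compound 4 is expected to give about 10%, somewhere between 0% and 25%.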

Compound 4, a percentage reported as inhibition, at one concentration (the size of the read-out at that concentration, not a potency): 6%
Beside the measured number, compound 4's estimate is 4 percentage points above it; the range from low to high includes it.
By their numbers in this assay, from the lowest: compounds 2, 4, 1 and 3 (each within the scatter of the next, the first and the last beyond it).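

In this assay, putting (2-((dimethylamino)methyl)-2-methylpropyl)amino in place of (3-(1H-imidazol-1-yl)propyl)(methyl)amino on a carbonyl carbon gives a number 5 percentage points lower from compound 1 to compound 4 (within the scatter), the first step read at this position. The five-membered aromatic ring can therefore go, and the amide hydrogen can come in, without a change that can be told from the scatter. Nothing measured here offers an explanation for this result.

Going by these compounds, what a carboxylic acid or a longer chain on this carbonyl carbon would give remains open. So does whether any group there can raise the inhibition beyond the scatter.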